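A few compounds are considered here, and "the series" means these few. Any claim that something is new, unique, unknown or untested is made for them only; others in the source may bear on it.

Of the compounds shown here, three that share one core have been tested in a functional assay on NCI-H1975 cells (Homo sapiens) for inhibition, read by CellTiter-Glo, with a stated time of 72 h; a higher number here means a weaker inhibitor of growth, a lower number a stronger inhibitor of growth. Compound 1 `C=CC(=O)Nc1cc(Nc2ncc(Cl)c(Nc3ccccc3S(=O)(=O)C(C)C)n2)c(OC)cc1N1CCC(N2CCN(C)CC2)CC1` gives 23 nM in this assay. Compound 2 `C=CC(=O)Nc1cc(Nc2ncc(Cl)c(Nc3ccccc3S(=O)(=O)C(C)C)n2)c(OC)cc1N1CCCN(C)CC1` gives 15 nM in this assay. Compound 3 `C=CC(=O)Nc1cc(Nc2ncc(Cl)c(Nc3cccc(C(F)(F)F)c3)n2)c(OC)cc1N1CCN(C)CC1` gives 260 nM in this assay, the highest of the three numbers; its gap to compound 1 and its gap to compound 2 both lie beyond the usual scatter, so compound 3 is the weakest inhibitor of growth among them. Within the data shown here, compound 1 and compound 2 differ from compound 3 in more than one place, so no single step between measured compounds is available.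

Compound 4 `C=CC(=O)Nc1cc(Nc2ncc(Cl)c(Nc3ccccc3S(=O)(=O)N(C)C)n2)c(OC)cc1N1CCN(C)CC1` is not yet measured. It differs from compound 3 by one change: 2-(dimethylsulfamoyl)phenyl in place of 3-(trifluoromethyl)phenyl on a nitrogen on an aromatic ring. Because compound 1 gives 23 nM and compound 2 gives 15 nM with groups of a related kind at that nitrogen, the expectation is that compound 4 moves toward lower numbers, well beyond the scatter. The expected step is a 7.4-fold lower number from compound 3 to compound 4 (0.87 log units; beyond the scatter), toward stronger growth inhibition. Compound 4 is therefore estimated to give about 35 nM in this assay, with a likely range from 10 nM to 120 nM.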

Compound 4, concentration for 50% growth inhibition: 31 nM
Compound 4: middle estimate off by 1.1-fold (0.05 log units), on the high side; low and high end bracket the measured number.
By their numbers in this assay, from the lowest: compounds 2, 1 and 4 (each within the scatter of the next, the first and the last beyond it); then compound 3.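

In this assay, putting 2-(dimethylsulfamoyl)phenyl in place of 3-(trifluoromethyl)phenyl on a nitrogen on an aromatic ring gives an 8.4-fold lower number from compound 3 to compound 4 (0.92 log units; beyond the scatter) while the rest of the molecule stays the same. The earlier compounds shown here differed from compound 3 in more than one place, so their lower numbers could not be tied to this nitrogen substituent alone, whereas this step shows that the substituent by itself can shift growth inhibition beyond the usual scatter. No supporting measurement is available to explain why this exchange has such an effect.

The exchange alters both the kind of group and its numbered place on the phenyl ring, so the compounds shown cannot tell how much of the step belongs to the sulfamoyl group and how much to where it sits. From the compounds shown here alone, it also remains open how a plain phenyl, or a phenyl carrying a carboxylic acid or an amine, would behave on the same nitrogen with the rest of compound 4 unchanged.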